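Dropping One Methoxy Group: Same Kind of Change, Different Surroundings

The source may report more compounds than this note shows. Statements on the series, on what has been measured and on what is new or still open speak of the compounds shown alone.

Compound 1 `CC(=O)N1N=C(c2cccc([N+](=O)[O-])c2)CC1c1ccccc1`: 8930 nM
Compound 2 `COc1ccc(C2CC(c3cccc([N+](=O)[O-])c3)=NN2C(C)=O)cc1`: 8210 nM
Compound 3 `COc1ccc(C2CC(c3ccc4ccccc4c3)=NN2CC=O)c(OC)c1OC`: 590 nM

These three compounds were tested in a functional assay on HEp-2 cells (Homo sapiens) for cytotoxicity, read by sulforhodamine B assay, with a stated time of 48 h; on this read-out lower numbers stand for stronger inhibition and higher numbers for weaker inhibition. Compound 3 gives the lowest number of the three, and both compound 1 and compound 2 lie beyond the scatter from it. Compound 2 and compound 1 differ in one place: hydrogen in place of methoxy on an aromatic carbon. That step measured a 1.1-fold higher number from compound 2 to compound 1 (0.04 log units; within the scatter).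

Compound 4 `COc1ccc(C2CC(c3ccc4ccccc4c3)=NN2CC=O)cc1OC` has not yet been measured in this assay. It differs from compound 3 in one place: hydrogen in place of methoxy on an aromatic carbon. The difference between the core of compound 3 and the core of compound 2 is not broken down here. The surroundings differ too: in compound 2 the methoxy sits para to a large group, whereas in compound 3 it sits ortho to a large group, ortho to a methoxy group and meta to a methoxy group, so this is the same kind of change, not the same change.

Because the step of a 1.1-fold higher number from compound 2 to compound 1 (0.04 log units; within the scatter) was within the scatter, a small step is expected from compound 3 to compound 4 in this assay, estimated as a 1.4-fold higher number from compound 3 to compound 4 (0.16 log units; within the scatter), though the different surroundings leave room for a larger shift. Compound 4 is therefore expected to give about 850 nM, estimated between 300 nM and 2500 nM.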

Compound 4, half-maximal inhibitory concentration: 1010 nM
Compound 4: the middle estimate sits 1.2-fold (0.07 log units) below what was measured; measured number inside the range.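

In this assay, putting hydrogen in place of one methoxy group gave a 1.7-fold higher number from compound 3 to compound 4 (0.23 log units; within the scatter). Set beside the earlier step on the other core, the change carried over with no difference that can be told from the scatter: the same change on two cores in this assay, a 1.1-fold higher number (0.04 log units; within the scatter) from compound 2 to compound 1 and a 1.7-fold higher number (0.23 log units; within the scatter) from compound 3 to compound 4, 1.6-fold (0.20 log units) apart, within the scatter of two such steps. This suggests that the change can be carried between these two cores with little effect, but two pairs in different surroundings do not show that it would hold on a third core or at other ring positions.

The compounds shown leave open whether the two methoxy groups still on compound 4 can also be replaced by hydrogen with so small a step. They also leave open what a hydroxyl group, a fluorine atom or an amine would do in place of methoxy.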